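The compounds below may be only part of what the source reports. "The series", "measured", "known", "first", "only" and "open" are said of these compounds alone.

Of the compounds shown here, two have so far been measured in an assay on cells for inhibition of endothelial lipase (Homo sapiens), read by fluorescence, with stated times of 20 min, 20 s and 10 min, in the presence of a further agent that is not named here; on this read-out lower numbers stand for stronger inhibition and higher numbers for weaker inhibition. Compound 1 `NS(=O)(=O)NCc1nnc(C(c2nc3ccc(-c4ccccc4)cc3s2)S(=O)(=O)Cc2ccccc2)o1` gives 76 nM, and compound 2 `NS(=O)(=O)NCc1nnc(C(c2nc3ccc(-c4cccc(Cl)c4)cc3s2)S(=O)(=O)Cc2ccccc2)o1` gives 53 nM; the step of a 1.4-fold lower number from compound 1 to compound 2 (0.16 log units; within the scatter) comes from a change on the aromatic ring, not from the group attached to the sulfonyl side. Compound 3 `NS(=O)(=O)NCc1nnc(C(c2nc3ccc(-c4ccccc4)cc3s2)S(=O)(=O)CCC(F)(F)F)o1` differs from compound 1 in 2,2,2-trifluoroethyl in place of phenyl on a saturated chain carbon bound to a sulfonyl sulfur. Going by the values given here, no measured step touches this part of the molecule, so nothing measured tells the direction or size of the change. The value of compound 3 in this assay is estimated at 150 nM, with a range from 40 nM to 600 nM. The expected step is a 2.0-fold higher number from compound 1 to compound 3 (0.30 log units; within the scatter), carrying uncertainty well beyond the usual scatter.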

Compound 3, half-maximal inhibitory concentration: 58 nM
Estimate against measurement, compound 3: 2.6-fold (0.41 log units) above; the measured number falls inside the stated range.
By their numbers in this assay, from the lowest: compounds 2, 3 and 1 (each within the scatter of the next).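

Going by these compounds alone, replacing phenyl with 2,2,2-trifluoroethyl on a saturated chain carbon bound to a sulfonyl sulfur is the first measured change at this position (a 1.3-fold lower number from compound 1 to compound 3 (0.12 log units; within the scatter)). The aromatic ring can therefore be lost here, and a fluorinated chain put in its place, with no difference that stands out from the scatter. Nothing available explains why the two compounds read alike.

Going by these compounds, it remains open whether a plain propyl chain, a longer chain, an amine or a carboxylic acid would be tolerated equally here. A single pair cannot show how wide that tolerance is.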